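The compounds below may be only part of what the source reports. "The series", "measured", "known", "first", "only" and "open" are said of these compounds alone.

Series notes. Compound 1 `COc1nc(-c2ccc(Br)cc2)ccc1[C@@H](c1ccccc1)[C@@](O)(CCN(C)C)c1cccc2ccccc12` is the reference point. In a toxicity assay on HeLa cells (Homo sapiens) for cytotoxicity (on this read-out higher numbers stand for lower toxicity in this test and lower numbers for higher toxicity in this test), compound 1 gives > 64 ug/mL, which is a limit of the assay and not a number. Compound 2 `COc1ncc(-c2ccccc2)cc1[C@@H](c1ccccc1)[C@@](O)(CCN(C)C)c1cc(F)ccc1F` belongs to the same series, but in this assay compound 2 has "nd" (no result reported), so no number is available for it either. Compound 1 therefore stands on a limit alone, with one further entry that carries no value, and its position among the results shown is given by the limit of > 64 ug/mL in this assay, at which 1 of the 2 values shown sits. Going by the values given here, no step between two measured compounds can be drawn from this material.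

Compound 3 `COc1nc(-c2ccc(C(F)(F)F)cc2)ccc1[C@@H](c1ccccc1)[C@@](O)(CCN(C)C)c1cccc2ccccc12` is the next compound to be measured. It differs from compound 1 by a single change, (trifluoromethyl in place of bromo on an aromatic carbon), in words trifluoromethyl in place of bromo on an aromatic carbon. Among the compounds with values here, with no measured step in hand, the expectation in this assay is no shift beyond the usual scatter. The expected step of a number no higher from compound 1 to compound 3 (the limit leaves the size open) is accordingly small. For compound 3 in this assay the estimate is 64 ug/mL, within a range from 25 ug/mL to 128 ug/mL, and a second limit rather than a number is the likelier outcome.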

Compound 3, half-maximal cytotoxic concentration: > 64 ug/mL
Compound 3: only a limit was reported; the forecaster's own chance of this, stated with the estimate: 70%; the middle value lies on the limit itself.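

In this assay compound 1 and compound 3 each give a limit of the assay and not a number, so no step can be read between them: the limit of > 64 ug/mL in this assay, at which 2 of the 3 values shown sit.

The compounds shown leave open whether trifluoromethyl in place of bromo on an aromatic carbon changes the half-maximal cytotoxic concentration at all.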